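Two measured compounds, one isomer still to test

The compounds below may be only part of what the source reports. "The series", "measured", "known", "first", "only" and "open" are said of these compounds alone.

Measured in a functional assay on NIH3T3 cells (Mus musculus) for inhibition, read by MTT assay, with a stated time of 72 h; a higher number here means a weaker inhibitor, a lower number a stronger inhibitor:
- compound 1 `C=C1CC[C@H]2[C@@](C)(CC[C@@H](OC(C)=O)[C@@]2(C)C(=O)OCc2ccccc2)[C@@H]1/C=C/C1=CCOC1=O`: 52700 nM
- compound 2 `C=C1CC[C@H]2[C@@](C)(CC[C@@H](OC(C)=O)[C@@]2(C)C(=O)OCc2ccccn2)[C@@H]1/C=C/C1=CCOC1=O`: 34900 nM

Going by the values given here, the only measured step is a 1.5-fold lower number from compound 1 to compound 2 (0.18 log units; within the scatter), with pyridin-2-yl in place of phenyl, so compound 1 is not set apart from its one neighbour. Compound 3 `C=C1CC[C@H]2[C@@](C)(CC[C@@H](OC(C)=O)[C@@]2(C)C(=O)OCc2ccccc2)[C@@H]1C/C=C1\C=COC1=O` has the same atoms as compound 1, joined differently: a group of 8 heavy atoms (6 carbon, 2 oxygen; one five-membered non-aromatic ring with 1 hetero atom) in place of a group of 8 heavy atoms (6 carbon, 2 oxygen; one five-membered non-aromatic ring with 1 hetero atom), on a saturated ring carbon. This change lies on a saturated ring carbon, and the measured step does not test it. With compound 1 at 52700 nM as the starting point, no step beyond the scatter is expected in this assay, in either direction. The estimated step is a 1.2-fold lower number from compound 1 to compound 3 (0.07 log units; within the scatter). For compound 3 the estimate is 45000 nM, with an expected range from 15000 nM to 110000 nM.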

Compound 3, half-maximal inhibitory concentration: 78000 nM
Beside the measured number, compound 3's estimate is 1.7-fold (0.24 log units) below it, and the stated range covers the measured number.
By their numbers in this assay, from the lowest: compounds 2, 1 and 3 (each within the scatter of the next, the first and the last beyond it).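

In this assay, joining the same atoms differently in the group on the saturated ring carbon gives a 1.5-fold higher number from compound 1 to compound 3 (0.17 log units; within the scatter), so this rearrangement does not set compound 3 apart from compound 1. Going by these compounds alone, the earlier pair differed only in phenyl against pyridin-2-yl, so this is the first reading at this position. No evidence available here explains the result. Still open, on these data alone, is whether a different group on this carbon, such as an amine or a carboxylic acid in place of the five-membered ring group, would move the number beyond the scatter.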